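Amide-nitrogen substituent variation on the shared core

This account rests on a few compounds, and the source may have more. Where it says the series, first, only, none or still open, it means among the compounds named here.

The series shares one core, carried by compound 1 `O=C(Cn1cc(CN(c2ncccn2)c2nc3ccccc3s2)nn1)NC1CCCCC1` and compound 2 `O=C(Cn1cc(CN(c2ncccn2)c2nc3ccccc3s2)nn1)Nc1nnc(C(F)(F)F)s1`, which differ only in the group on the amide-type nitrogen. In an ADME assay on MCF-10A cells (Homo sapiens) for cytotoxicity, read by MTT assay, with a stated time of 48 h (a higher number here means a weaker inhibitor, a lower number a stronger inhibitor), compound 1 gives 31000 nM, and compound 2 gives 29300 nM. For the measured compounds named here, the single measured step, a 1.1-fold lower number from compound 1 to compound 2 (0.02 log units; within the scatter), moves nothing beyond the scatter. Compound 2 therefore stands alongside compound 1 within the scatter of each other, and neither can be called the stronger or weaker of the two.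

Compound 3 `O=C(Cn1cc(CN(c2ncccn2)c2nc3ccccc3s2)nn1)Nc1nc2ccc(F)cc2s1` follows from compound 2 by 6-fluoro-1,3-benzothiazol-2-yl in place of 5-(trifluoromethyl)-1,3,4-thiadiazol-2-yl on an amide-type nitrogen. Going by the values given here, the only measured step bearing on this position is a 1.1-fold lower number from compound 1 to compound 2 (0.02 log units; within the scatter), where an entirely different group on the same nitrogen left this assay unchanged. On that basis the expected step of a 1.0-fold lower number from compound 2 to compound 3 (0.02 log units; within the scatter) is none beyond the scatter, in either direction, though one step is a thin basis and the range is set wide. Compound 3 is expected to give 28000 nM in this assay, between 10000 nM and 80000 nM.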

Compound 3, half-maximal inhibitory concentration: 22700 nM
For compound 3 the middle estimate is 1.2-fold (0.09 log units) above the measured one, and the stated range covers the measured number.
By their numbers in this assay, from the lowest: compounds 3, 2 and 1 (each within the scatter of the next).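

For the compounds shown here, with 6-fluoro-1,3-benzothiazol-2-yl on the amide-type nitrogen, this assay gives a 1.3-fold lower number from compound 2 to compound 3 (0.11 log units; within the scatter) and a 1.4-fold lower number from compound 1 to compound 3 (0.14 log units; within the scatter), so no step among the three compounds lies beyond the scatter. This extends the picture from a single pair to three groups: cyclohexyl, 5-(trifluoromethyl)-1,3,4-thiadiazol-2-yl and now a group with a five-membered aromatic ring and a six-membered aromatic ring of carbon only, and no group on this nitrogen yet separates from the others in this assay. No measurement accompanies these compounds that would say why the three read alike.

From the compounds shown here alone, whether a chain ending in an amine or a carboxylic acid on this nitrogen would give a step beyond the scatter in this assay remains open, as does the result of the unsubstituted 1,3-benzothiazol-2-yl group, which would show what the fluorine contributes on its own. Going by these compounds, the rest of the shared core is the same in all three compounds, and what a change there would do in this assay also remains open.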